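The compounds below may be only part of what the source reports. "The series", "measured", "known", "first", "only" and "open" are said of these compounds alone.

In a functional assay on PC-3 cells (Homo sapiens) for antiproliferative activity, read by MTT assay, with a stated time of 12 h (a lower number here means a stronger inhibitor, a higher number a weaker inhibitor), compound 1 `COc1ccc2c(=O)cc(/C=C/c3ccc(OC(F)(F)F)cc3)oc2c1` gives only a limit, > 40000 nM. Compound 2 `COc1cc(OC)c2c(=O)cc(/C=C/c3ccc(Br)cc3)oc2c1` likewise gives only a limit, > 40000 nM. Both values thus rest at the same point, (the limit of > 40000 nM in this assay, at which 2 of the 2 values shown sit), so compound 2 stands level with compound 1 and nothing separates the two. Compound 3 `COc1cc(OC)c2c(=O)cc(/C=C/c3ccc([N+](=O)[O-])cc3)oc2c1` differs from compound 2 by nitro in place of bromo on an aromatic carbon. With both neighbours at the limit, no step beyond the scatter is expected from compound 2 to compound 3 in this assay, and the estimated step is a step that the limit leaves unreadable from compound 2 to compound 3. Compound 3 is therefore expected to give about 60000 nM, between 20000 nM and 200000 nM.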

Compound 3, half-maximal inhibitory concentration: > 40000 nM
Compound 3: a limit, no number (the forecaster's own chance of this, stated with the estimate: 80%); the middle value lies beyond the limit too.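

Going by these compounds alone, compound 3, like compound 2, gives only a limit, so no step between compound 2 and compound 3 can be read: the limit of > 40000 nM in this assay, at which 3 of the 3 values shown sit. In this assay the compounds shown leave open how nitro and bromo compare, and which change to the shared core would give a measured number.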